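The source may hold more compounds than are shown below. What is called first, only, known or untested is meant among the compounds shown, and "the series" means these compounds.

Compound 2 `Cc1cccc(NC(=S)N/N=C/c2ccc3ccccc3n2)c1` is the starting point of this account. In a functional assay on HL-60 cells (Homo sapiens) for antiproliferative activity, read by sulforhodamine B assay, with a stated time of 72 h (a higher number here means a weaker inhibitor, a lower number a stronger inhibitor), compound 2 gives > 100000 nM, which is a limit of the assay and not a number. Compound 1 `COc1ccc(C)cc1NC(=S)N/N=C/c1ccc2ccccc2n1` differs from it in one place, and the step that the two limits leave unreadable from compound 1 to compound 2 cannot be sized. In this assay compound 1 gives > 100000 nM, again a limit. Compound 3 `NC(=S)N/N=C/c1nc2ccccc2s1` carries a different core. In this assay compound 3 gives > 100000 nM, also a limit. Taken together, the evidence amounts to the limit of > 100000 nM in this assay, at which 3 of the 3 values shown sit, so no measured step has a readable size.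

Compound 4 `S=C(N/N=C/c1ccc2ccccc2n1)Nc1cccc(Cl)c1` has not yet been measured. It differs from compound 2 by chloro in place of methyl on an aromatic carbon. Within the data shown here, the only measured step that touches this ring is the one from compound 1 to compound 2, and it is unreadable. With nothing readable to build on, no step beyond the scatter is expected, and the step of a number no higher from compound 2 to compound 4 (the limit leaves the size open) is therefore estimated to be essentially none. Compound 4 is accordingly expected to give 100000 nM in this assay, estimated between 30000 nM and 300000 nM, most likely reported as a limit once more.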

Compound 4, half-maximal inhibitory concentration: 28800 nM
Beside the measured number, compound 4's estimate is 3.5-fold (0.54 log units) above it; the whole stated range lies above it.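

In this assay, the change from 3-methylphenyl to 3-chlorophenyl gives the only readable step shown so far: an at least 3.4-fold lower number from compound 2 to compound 4 (0.54 log units; beyond the scatter). It shows that a change at this position, meta to a large group on the six-membered aromatic ring of carbon only, can shift the read-out beyond the scatter, whereas the other step on this ring cannot be read. Compound 4 is the only compound shown with a value that is not a limit, and the others stay at that limit: the limit of > 100000 nM in this assay, at which 3 of the 4 values shown sit.

The compounds shown leave open whether chloro is unusual at this position or whether fluoro, bromo, trifluoromethyl or an amine there would give a similar step. They also leave open whether the same change gives a similar step on another core, such as that of compound 3.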